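This account rests on a few compounds, and the source may have more. Where it says the series, first, only, none or still open, it means among the compounds named here.

Measured so far:
compound 1 `CCc1nc(-c2ccc(Cl)cc2Cl)c(CC)nc1NC(CC)CC` — 0.283 h
compound 2 `CCc1nc(-c2ccc(Cl)cc2Cl)c(CC)nc1CC(CC)CC` — 0.217 h
compound 3 `CCCN(CCN(C)C)c1nc(CC)c(-c2ccc(Cl)cc2Cl)nc1CC` — 0.0833 h

In an in vitro ADME assay on microsomes (Homo sapiens) for metabolic stability (on this read-out lower numbers stand for a shorter-lived compound and higher numbers for a longer-lived compound), compound 3 gives the lowest of the three numbers; the steps of a 3.4-fold lower number from compound 1 to compound 3 (0.53 log units; beyond the scatter) and a 2.6-fold lower number from compound 2 to compound 3 (0.42 log units; beyond the scatter) both lie beyond the scatter. Compound 4 `CCc1nc(-c2ccc(Cl)cc2Cl)c(CC)nc1NC(C1CC1)C1CC1` differs from compound 3 in one place: (dicyclopropylmethyl)amino in place of (2-(dimethylamino)ethyl)(propyl)amino on an aromatic carbon. The group entering resembles the (pentan-3-yl)amino of compound 1, so the step that bears most on this change is a 3.4-fold lower number from compound 1 to compound 3 (0.53 log units; beyond the scatter), read in reverse. A modest rise in this assay is therefore expected, a 3.0-fold higher number from compound 3 to compound 4 (0.48 log units; beyond the scatter), because a 3.4-fold lower number from compound 1 to compound 3 (0.53 log units; beyond the scatter) was itself modest. Compound 4 is estimated at 0.25 h, with a range from 0.1 h to 0.6 h.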

Compound 4, half-life: 0.183 h
For compound 4 the middle estimate is 1.4-fold (0.14 log units) above the measured one; the measured number falls inside the stated range.
By their numbers in this assay, from the lowest: compound 3; then compounds 4, 2 and 1 (each within the scatter of the next).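

In this assay, (dicyclopropylmethyl)amino in place of (2-(dimethylamino)ethyl)(propyl)amino gives a step beyond the scatter (a 2.2-fold higher number from compound 3 to compound 4 (0.34 log units; beyond the scatter)), so the higher number is not tied to the (pentan-3-yl)amino group of compound 1. Dicyclopropylmethyl and pentan-3-yl on the nitrogen cannot be told apart (a 1.5-fold lower number from compound 1 to compound 4 (0.19 log units; within the scatter)), nor can (dicyclopropylmethyl)amino and 2-ethylbutyl (a 1.2-fold lower number from compound 2 to compound 4 (0.07 log units; within the scatter)), which leaves compound 3 alone apart from the other three. No measurement here accounts for this. As far as these compounds go, whether a dipropylamino or morpholine group at this place would fall with compound 3 or with the other three stays open.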